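The compounds below may be only part of what the source reports. "The series", "measured", "known", "first", "only" and "open" are said of these compounds alone.

Measured so far:
compound 1 (`O=C(Nc1ccc(Oc2ccnc3[nH]ccc23)cc1)c1cc2cccnc2n(-c2ccc(F)cc2)c1=O`): in a functional assay on NCI-H460 cells (Homo sapiens) for antiproliferative activity, read by MTT assay, with a stated time of 72 h (a higher number here means a weaker inhibitor, a lower number a stronger inhibitor), compound 1 gives 190 nM.
compound 2 (`O=C(Nc1ccc(Oc2ccnc3[nH]ccc23)cc1)c1cc2cccnc2n(-c2ccc(Cl)cc2)c1=O`): in this assay compound 2 gives 290 nM.
compound 3 (`O=C(Nc1ccc(Oc2ccnc3[nH]ccc23)cc1)c1cc2cccnc2n(-c2ccc(Br)cc2)c1=O`): in this assay compound 3 gives "not determined" (no result reported).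

Compound 3 thus stands nowhere on the numbers; it carries only its structure, with bromo where compound 1 has fluoro and compound 2 has chloro. Compound 4 (`COc1ccc(-n2c(=O)c(C(=O)Nc3ccc(Oc4ccnc5[nH]ccc45)cc3)cc3cccnc32)cc1`) differs from compound 3 by methoxy in place of bromo on an aromatic carbon. Among the compounds with values here, the only measured step at this place is a 1.5-fold higher number from compound 1 to compound 2 (0.18 log units; within the scatter), a halogen exchange that stayed within the scatter. Within the data shown here, no measured pair exchanges a halogen for methoxy, so the size of the step in this assay for compound 4 cannot be read from the data; the halogen pair gives no sign of a shift beyond the scatter at this place. Compound 4 is expected at 260 nM, between 100 nM and 700 nM.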

Compound 4, half-maximal inhibitory concentration: 960 nM
The estimate for compound 4 lay 3.7-fold (0.57 log units) below the measured number; measured number outside the range, above it.
By their numbers in this assay, from the lowest: compounds 1 and 2 (each within the scatter of the next); then compound 4.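

In this assay, a 3.3-fold higher number from compound 2 to compound 4 (0.52 log units; beyond the scatter) and a 5.1-fold higher number from compound 1 to compound 4 (0.70 log units; beyond the scatter) show that this place on the outer phenyl ring is not indifferent to its substituent. Methoxy gives a step beyond the scatter, which the exchange of fluoro and chloro did not. Nothing available accounts for this shift.

Compound 3 has no number, so steps involving bromo cannot be read. As far as these compounds go, whether methyl, an amine or a carboxylic acid at this place would stay with the fluoro and chloro compounds or go with methoxy remains open.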